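Shortening the ether chain on the aryl oxygen

The source may hold more compounds than are shown below. What is called first, only, known or untested is meant among the compounds shown, and "the series" means these compounds.

Of the compounds shown here, three have been measured in an ADME assay; a lower number here means that the compound disappears faster, a higher number that the compound lasts longer. Compound 1, `COc1ccc(C[S+]([O-])c2ncccc2C(=O)Nc2ccncc2)c(OC)c1OC`, gives 0.45 h. Compound 3, `COc1cc(OC)c(C[S+]([O-])c2ncccc2C(=O)Nc2ccncc2)cc1Br`, gives 0.07 h. For compound 2, `COCOCCOc1cc(OC)ccc1C[S+]([O-])c1ncccc1C(=O)Nc1ccncc1`, the read-out is a limit and not a number: compound 2 gives < 0.02 h, which is the limit of < 0.02 h in this assay, at which 1 of the 3 values shown sits. Compound 2 therefore stands at the short-lived end of the three, with its true half-life unknown beyond that boundary, while compound 1 and compound 3 both return real numbers.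

Compound 4, `COCOc1cc(OC)ccc1C[S+]([O-])c1ncccc1C(=O)Nc1ccncc1`, is the next compound to be measured in this assay. It differs from compound 2 in one place: methoxy in place of (methoxymethoxy)methyl on a saturated chain carbon bound to an oxygen on an aromatic ring. The remaining structure, the sulfoxide link and the amide, is unchanged.

Among the measured compounds shown here, no measured pair shares this exact change, so the size of the step is open. The expected direction is toward a longer half-life, although a modest one, and it may well remain within the scatter. The estimate for compound 4 is 0.03 h, with a range from 0.01 h to 0.12 h. The step this estimate implies is an at least 1.5-fold higher number from compound 2 to compound 4 (0.17 log units; that floor lies within the scatter), and there is a fair chance that compound 4 again returns only a limit.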

Compound 4, half-life: < 0.02 h
Compound 4 gave a limit, no number; the forecaster's own chance of this, stated with the estimate: 35%; at least 1.5-fold (0.17 log units) between middle value and limit.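

In this assay compound 4 gives < 0.02 h, a limit and not a number. Compound 2 gives < 0.02 h, also a limit, so no step between the two compounds can be read: the limit of < 0.02 h in this assay, at which 2 of the 4 values shown sit.

As far as these compounds go, whether going from 2-(methoxymethoxy)ethoxy to methoxymethoxy changes the half-life at all remains open.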